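Aryl swap on the ring nitrogen: outlook for compound 4

The source may hold more compounds than are shown below. What is called first, only, known or untested is meant among the compounds shown, and "the series" means these compounds.

The three measured compounds share one core. Compound 1 is `O=C(COCc1ccccc1)N1CCN(c2ccccc2Cl)CC1`, compound 2 is `O=C(COCc1ccccc1)N1CCN(c2cccc(Cl)c2)CC1` and compound 3 is `O=C(COCc1ccccc1)N1CCN(c2ccc(F)cc2Cl)CC1`. In a functional assay on HEK293 cells for positive allosteric modulation of metabotropic glutamate receptor 5 (Homo sapiens), read by FLIPR and calcium flux (on this read-out lower numbers stand for an effect already at smaller amounts and higher numbers for an effect only at larger amounts of compound), compound 1 gives 1100 nM, the second highest of the three numbers; compound 2 gives 6700 nM and compound 3 gives 270 nM. Replacing 2-chlorophenyl by 3-chlorophenyl gives a 6.1-fold higher number from compound 1 to compound 2 (0.78 log units; beyond the scatter), adding fluoro gives a 4.1-fold lower number from compound 1 to compound 3 (0.61 log units; beyond the scatter), and between the remaining pair a 25-fold lower number from compound 2 to compound 3 (1.39 log units; beyond the scatter).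

Compound 4 is `O=C(COCc1ccccc1)N1CCN(c2ccncc2)CC1` and is not yet measured. It differs from compound 1 thus: pyridin-4-yl in place of 2-chlorophenyl on an amine nitrogen in a ring. Among the measured compounds shown here, no measured step removes the chlorine or brings a ring nitrogen into the aryl group, so nothing bears on it directly. The nearest hint is that moving the chlorine away from its place in compound 1 already raised the number because of a 6.1-fold higher number from compound 1 to compound 2 (0.78 log units; beyond the scatter); losing it altogether and adding a ring nitrogen is a larger departure. A higher number is therefore expected, a 4.5-fold higher number from compound 1 to compound 4 (0.66 log units; beyond the scatter), with wide uncertainty. Compound 4 is estimated at 5000 nM, within 1500 nM to 20000 nM.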

Compound 4, half-maximal effective concentration: > 25000 nM
Compound 4 was reported as a limit; the forecaster's own chance of this, stated with the estimate: 30%; middle value at least 5.0-fold (0.69 log units) away from the limit.
By their numbers in this assay, from the lowest: compound 3; then compound 1; then compound 2. At a limit, above all of these: compound 4.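

Compound 4 reads as a limit of the assay, not as a number, in this assay: the limit of > 25000 nM in this assay, at which 1 of the 4 values shown sits.

Read against that limit, this position proves far less forgiving than the shift of the chlorine alone showed: pyridin-4-yl gives an at least 22-fold higher number from compound 1 to compound 4 (1.35 log units; beyond the scatter) and an at least 92-fold higher number from compound 3 to compound 4 (1.96 log units; beyond the scatter). Even the 3-chlorophenyl group keeps a lower number, with an at least 3.7-fold higher number from compound 2 to compound 4 (0.57 log units; beyond the scatter), so all three chlorine-bearing aryl groups give lower numbers than pyridin-4-yl, and each of these steps marks only a minimum size.

Still open, on these data alone, is whether the loss of the chlorine or the entry of the ring nitrogen carries this step, a question that an unsubstituted phenyl group on the same ring nitrogen would help to settle. Also open, as far as these compounds go, is whether a methyl or a methoxy group can stand in for the chlorine of the 2-chlorophenyl group.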